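A few compounds are considered here, and "the series" means these few. Any claim that something is new, unique, unknown or untested is made for them only; others in the source may bear on it.

Measured in a functional assay on MDA-MB-231 cells (Homo sapiens), read by wound healing assay, with a stated time of 24 h; on this read-out higher numbers stand for weaker inhibition and lower numbers for stronger inhibition:
- Compound 1 `CC(C)=CCC[C@H](C)c1ccc(C)c(CNCCO)c1O`: > 20000 nM, a limit
- Compound 2 `CC(C)=CCC[C@H](C)c1ccc(C)c2c1OCN(CCCCCO)C2`: 10000 nM

Compound 1 has no number of its own, only a limit: the limit of > 20000 nM in this assay, at which 1 of the 2 values shown sits. Compound 3 `CC(C)=CCC[C@H](C)c1ccc(C)c(CO)c1O` keeps the core of compound 1 and differs in one place, on a saturated chain carbon bound to an aromatic carbon, where hydroxy stands in place of (2-hydroxyethyl)amino: hydroxy in place of (2-hydroxyethyl)amino on a saturated chain carbon bound to an aromatic carbon. Among the compounds with values here, no measured step between compounds differing in one place is available to size this change. Within the data shown here, the only actual number comes from compound 2, at 10000 nM, so a value in that region is the expectation for compound 3. In this assay a modest move toward stronger inhibition is expected, and compound 3 may also remain at the limit. The expected change is an at least 1.3-fold lower number from compound 1 to compound 3 (0.12 log units; that floor lies within the scatter). For compound 3 the estimated value is 15000 nM, with an expected range from 6000 nM to 30000 nM.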

Compound 3, half-maximal inhibitory concentration: 12300 nM
Estimate against measurement, compound 3: 1.2-fold (0.09 log units) above; the measured number falls inside the stated range.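

In this assay, within the data shown here, hydroxy in place of (2-hydroxyethyl)amino on a saturated chain carbon bound to an aromatic carbon gives an at least 1.6-fold lower number from compound 1 to compound 3 (0.21 log units; that floor lies within the scatter) as the only sized change at this position. With this change, compound 3 gives 12300 nM as an actual number. The value of compound 1 remains a limit, so the step is known only as a floor: the limit of > 20000 nM in this assay, at which 1 of the 3 values shown sits.

From the compounds shown here alone, whether the true step lies beyond the usual scatter stays open. Also open, going by these compounds, is how an amine without the hydroxyethyl chain, a carboxylic acid or a longer chain ending in hydroxy would read on that same carbon in this assay with the rest of the core of compound 1 unchanged.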